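Urea versus amide at the terminal aryl group

The source may hold more compounds than are shown below. What is called first, only, known or untested is meant among the compounds shown, and "the series" means these compounds.

Measured so far:
Compound 1 `O=C(Nc1cccc(-n2cc(-c3ccncc3)c(-c3ccc(Cl)c(O)c3)n2)c1)Nc1cccc(C(F)(F)F)c1`: 6130 nM
Compound 2 `COc1cc(-c2nn(-c3cccc(NC(=O)Nc4cc(C(F)(F)F)cc(C(F)(F)F)c4)c3)cc2-c2ccncc2)ccc1Cl`: 1230 nM
Compound 3 `COc1cc(-c2nn(-c3cccc(NC(=O)c4cccc(C(F)(F)F)c4)c3)cc2-c2ccncc2)ccc1Cl`: 2980 nM

All three compounds were tested in a functional assay on OVCAR-3 cells (Homo sapiens) for inhibition, read by sulforhodamine B assay, with a stated time of 48 h; on this read-out lower numbers stand for stronger inhibition of growth and higher numbers for weaker inhibition of growth. Among the three numbers, compound 3 holds the second highest. Its nearest neighbour is compound 1, whose number is higher than that of compound 3 by a margin beyond the usual scatter, while compound 2 gives the lowest number, again by a margin beyond the scatter.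

Compound 4 `COc1cc(-c2nn(-c3cccc(NC(=O)Nc4ccc(Cl)c(Cl)c4)c3)cc2-c2ccncc2)ccc1Cl` has not yet been measured. It differs from compound 3 in one place: (3,4-dichlorophenyl)amino in place of 3-(trifluoromethyl)phenyl on a carbonyl carbon. The carbonyl is thereby turned from an amide into a urea, the same linking unit that compound 2 carries, and compound 2 gives 1230 nM in this assay.

Going by the values given here, no pair of measured compounds isolates exactly this change, so the expectation rests on compound 2 and compound 3 alone. A move toward a lower number is expected, of a size that goes beyond the scatter; the estimated step is a 2.0-fold lower number from compound 3 to compound 4 (0.30 log units; within the scatter). For compound 4 the expected value is 1500 nM, within a range from 500 nM to 4500 nM.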

Compound 4, concentration for total growth inhibition: 2270 nM
For compound 4 the middle estimate is 1.5-fold (0.18 log units) below the measured one; the measured number falls inside the stated range.
By their numbers in this assay, from the lowest: compounds 2, 4 and 3 (each within the scatter of the next, the first and the last beyond it); then compound 1.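

In this assay, putting (3,4-dichlorophenyl)amino in place of 3-(trifluoromethyl)phenyl on the carbonyl carbon gives a 1.3-fold lower number from compound 3 to compound 4 (0.12 log units; within the scatter), so this exchange leaves the two compounds indistinguishable on this read-out. The exchange turns an amide into a urea, adds a hydrogen-bond donor and replaces trifluoromethyl with two chlorines, yet this shared core tolerates all of that together without a change that stands clear of the scatter. Nothing measured here explains this outcome, and these changes arrive together, so their separate contributions cannot be read.

Going by these compounds, whether the urea link or the ring substituents matter more remains open, and a 3,4-dichlorophenyl amide would separate the two. On these data alone, how a sulfonamide in place of the carbonyl link would read on this core also remains open.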